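Swapping a Hydroxy for an Octyl Chain

A few compounds are considered here, and "the series" means these few. Any claim that something is new, unique, unknown or untested is made for them only; others in the source may bear on it.

Compound 1 `CN1CCN(c2nc3ccccc3n2CCO)CC1` was tested in a functional assay on ileum for inhibition of histamine H1 receptor (Cavia porcellus) (a lower number here means a stronger inhibitor, a higher number a weaker inhibitor), where compound 1 gives 410 nM. Within the data shown here, that is the higher of the two numbers known so far, the other belonging to compound 2 `C=CCOCCn1c(N2CCCN(C)CC2)nc2ccccc21`, which gives 10 nM. Compound 3 `CCCCCCCCCCn1c(N2CCN(C)CC2)nc2ccccc21` is not yet measured. It differs from compound 1 by octyl in place of hydroxy on a saturated chain carbon, two bonds along the chain from an aromatic nitrogen. Among the measured compounds shown here, no measured pair shows this exact change, so the expected size rests on compound 2, whose 10 nM shows that a far lower number is reachable here. The step from compound 1 to compound 3 is expected to be a 10-fold lower number from compound 1 to compound 3 (1.01 log units; beyond the scatter), a clear fall. Compound 3 is estimated at 40 nM, ranging from 6 nM to 250 nM.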

Compound 3, half-maximal inhibitory concentration: 4200 nM
Estimate against measurement, compound 3: 110-fold (2.02 log units) below; the whole stated range lies below it.
By their numbers in this assay, from the lowest: compound 2; then compound 1; then compound 3.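

At this place on the chain, the exchange is far from neutral: in this assay, octyl in place of hydroxy gives a 10-fold higher number from compound 1 to compound 3 (1.01 log units; beyond the scatter), so compound 3 is the weaker inhibitor of this pair. This single pair shows that what sits on the chain here can move the number strongly, and that a long carbon chain does not lower it. Nothing measured here explains the rise.

Still open, as far as these compounds go, is whether the step comes from losing the hydroxy or from gaining the octyl. A methoxy group, an amine or a short ethyl chain at the same place could help separate the two.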